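The compounds below may be only part of what the source reports. "The series", "measured", "known", "first", "only" and "open" are said of these compounds alone.

Compound 1 `O=C(/C=C\Nc1ccc(C(F)(F)F)cc1)c1cn(-c2ccccc2)nc1-c1ccc(F)cc1` gives > 50000 nM in a functional assay on A549 cells (Homo sapiens) for antiproliferative activity, read by MTT assay, with a stated time of 48 h; a higher number here means a weaker inhibitor, a lower number a stronger inhibitor.
Compound 2 `O=C(/C=C\Nc1ccc(Cl)cc1)c1cn(-c2ccccc2)nc1-c1ccc(Cl)cc1` gives 3670 nM in this assay.

The value for compound 1 is a limit of the assay, not a number. For the measured compounds named here, compound 2 therefore stands as the only actual number in this set. Its companion sits at the limit of > 50000 nM in this assay, at which 1 of the 2 values shown sits. Going by the values given here, no step between two measured compounds that differ in a single place is available here, so there is no measured step to lean on.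

Compound 3 `O=C(/C=C\Nc1ccc(C(F)(F)F)cc1)c1cn(-c2ccccc2)nc1-c1ccc(Cl)cc1` differs from compound 2 in one place: trifluoromethyl in place of chloro on an aromatic carbon. Cut one bond further out, the same change reads (4-chlorophenyl)amino to (4-(trifluoromethyl)phenyl)amino. Compound 3 thus shares its trifluoromethyl-bearing anilino part with compound 1, while its other aryl group is that of compound 2.

For this step a loss of potency beyond the usual scatter is expected, and it would not be surprising if only a limit were reported. Compound 3 is expected to give about 15000 nM in this assay, within 4000 nM to 50000 nM, which means an expected step of a 4.1-fold higher number from compound 2 to compound 3 (0.61 log units; beyond the scatter).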

Compound 3, half-maximal inhibitory concentration: > 50000 nM
Compound 3 ended at the assay's limit; the forecaster's own chance of this, stated with the estimate: 35%; middle value at least 3.3-fold (0.52 log units) from the limit.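

For the compounds shown here, this is the first comparison in the set between two compounds that differ in one place, and it shows that (4-chlorophenyl)amino cannot be exchanged for (4-(trifluoromethyl)phenyl)amino without a heavy cost in this assay: the change brings an at least 13-fold higher number from compound 2 to compound 3 (1.13 log units; beyond the scatter). The step between compound 1 and compound 3, chloro in place of fluoro on the other aryl group, cannot be read, as both values are limits, so nothing can be said about that halogen swap while trifluoromethyl is present. Compound 2 remains the only compound with an actual number, and the set now reads: the limit of > 50000 nM in this assay, at which 2 of the 3 values shown sit.

Still open, going by these compounds, is whether this loss is particular to trifluoromethyl or follows any departure from chloro, a question that a methyl, methoxy or nitrile group in the same place would help to answer. Also open, on these data alone, is whether the other aryl group matters when the chloro on the anilino part is kept, which a compound pairing that chloro with fluoro on the other aryl group would show.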